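Swapping the para hydroxy for a carboxy group

The compounds below may be only part of what the source reports. "The series", "measured", "known", "first", "only" and "open" are said of these compounds alone.

Measured compounds:
compound 1, `O=C(CCCCCc1ccc(Br)cc1)N1CCOC1=O`, 8510 nM
compound 2, `CSc1ccc(CCCCCC(=O)N2CCOC2=O)cc1`, > 20000 nM
compound 3, `O=C(CCCCCc1ccc(O)cc1)N1CCOC1=O`, 61 nM

Three compounds share one core and differ only in the group on the aromatic ring. In an assay on HEK293 cells for inhibition of N-acylethanolamine-hydrolyzing acid amidase (Rattus norvegicus), read by LC-MS, with a stated time of 30 min (a lower number here means a stronger inhibitor, a higher number a weaker inhibitor), compound 1 gives 8510 nM. For compound 2 the assay reports only a limit, > 20000 nM, not a number (the limit of > 20000 nM in this assay, at which 1 of the 3 values shown sits). Compound 3, with a hydroxy group, gives 61 nM and stands lowest of the two numbers; the nearest is compound 1, reached by a 140-fold lower number from compound 1 to compound 3 (2.14 log units; beyond the scatter). The change from compound 2 to compound 3 was an at least 320-fold lower number from compound 2 to compound 3 (2.51 log units; beyond the scatter).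

Compound 4, `O=C(O)c1ccc(CCCCCC(=O)N2CCOC2=O)cc1`, carries carboxy in place of hydroxy on an aromatic carbon. For the measured compounds named here, no measured step involves a carboxy group, so the evidence is indirect: both known changes to the group at this position were large, and hydroxy was the only one of the three that gave a strong inhibitor. A carboxy group is a different kind of group, so the expectation is a return towards weaker inhibition, with a step in this assay of a 25-fold higher number from compound 3 to compound 4 (1.39 log units; beyond the scatter). Compound 4 is therefore estimated at 1500 nM, in a range from 200 nM to 15000 nM.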

Compound 4, half-maximal inhibitory concentration: > 20000 nM
Compound 4 gave a limit, no number (the forecaster's own chance of this, stated with the estimate: 15%); middle value at least 13-fold (1.12 log units) from the limit.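

Hydroxy and carboxy carry the same counts of hydrogen-bond donors and acceptors and no net charge, yet these counts do not preserve inhibition at this place, para to a large group, as carboxy in place of hydroxy gives an at least 320-fold higher number from compound 3 to compound 4 (2.51 log units; beyond the scatter). Compound 4 also falls short of the bromo compound, with an at least 2.3-fold higher number from compound 1 to compound 4 (0.37 log units; beyond the scatter), so among the four groups shown, hydroxy remains the only one that gives a strong inhibitor, and even a group that contains a hydroxy-like oxygen and hydrogen does not match it. The value of compound 4 is a limit, not a number, so its step from compound 2 cannot be read, and how much weaker compound 4 really is stays hidden: the limit of > 20000 nM in this assay, at which 2 of the 4 values shown sit.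

The compounds shown leave open whether the hydrogen of the hydroxy group matters, which a methoxy group at the same place could test. They also leave open whether an amine or a hydroxymethyl group would keep the strength of compound 3, or whether only hydroxy itself does so.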